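From azido to ethyl: what the fluoro step suggests

A few compounds are considered here, and "the series" means these few. Any claim that something is new, unique, unknown or untested is made for them only; others in the source may bear on it.

In a functional assay on OCI-Ly7 cells (Homo sapiens) for antiproliferative activity, read by WST assay, with a stated time of 3 days (a higher number here means a weaker inhibitor, a lower number a stronger inhibitor), compound 1 `[N-]=[N+]=Nc1cc(=O)[nH]c(=O)n1[C@@H]1O[C@H](CO)[C@@H](O)[C@H]1O` gives > 50000 nM, which is a limit of the assay and not a number. Within the data shown here, compound 2 `[N-]=[N+]=Nc1c(F)c(=O)[nH]c(=O)n1[C@@H]1O[C@H](CO)[C@@H](O)[C@H]1O` gives 700 nM, the only actual number so far. Fluoro in place of hydrogen on an aromatic carbon accounts for an at least 71-fold lower number from compound 1 to compound 2 (1.85 log units; beyond the scatter), a large step. Compound 3 `CCc1c(F)c(=O)[nH]c(=O)n1[C@@H]1O[C@H](CO)[C@@H](O)[C@H]1O` keeps that fluoro but has ethyl in place of azido on an aromatic carbon. Among the measured compounds shown here, no measured step changes the azido group, so the evidence here is only indirect. The fluoro step, an at least 71-fold lower number from compound 1 to compound 2 (1.85 log units; beyond the scatter), shows that one small change to the shared core can move the number a long way. A sizeable move towards a weaker inhibitor in this assay is therefore expected, though its size is very uncertain. The estimated change is a 7.1-fold higher number from compound 2 to compound 3 (0.85 log units; beyond the scatter). Compound 3 is expected to give 5000 nM, within an estimated range from 500 nM to 50000 nM.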

Compound 3, half-maximal inhibitory concentration: 1900 nM
Beside the measured number, compound 3's estimate is 2.6-fold (0.42 log units) above it; low and high end bracket the measured number.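

Replacing azido with ethyl on this aromatic carbon, with the fluoro group kept, gives a 2.7-fold higher number from compound 2 to compound 3 (0.43 log units; beyond the scatter) in this assay, so this position responds to a change of group, but far less than the fluoro step might have implied. The azido group is therefore not required for measurable activity in this series, since ethyl, which has no hydrogen-bond acceptor and no double bond, can take its place and still give a real number. Compound 1 alone rests on a limit of the assay and not a number: the limit of > 50000 nM in this assay, at which 1 of the 3 values shown sits.

How much the fluoro group matters alongside ethyl stays open, as the fluoro step is shown only with azido in place. So does the effect of an amine, a methoxy group or a longer chain such as propyl at this position.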